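A few compounds are considered here, and "the series" means these few. Any claim that something is new, unique, unknown or untested is made for them only; others in the source may bear on it.

Compound 3 `c1ccc2c(c1)CC2CN1CCN(c2cccc3c2OCCCO3)CC1` was examined in a functional assay on the whole organism for agonist activity, with Rattus norvegicus as the target; a higher number here means that more compound is needed for the effect, a lower number that less compound is needed. In this assay compound 3 gives only a limit, > 10 mg/kg, and not a number. Compound 3 therefore stands at the limit of > 10 mg/kg in this assay, at which 1 of the 3 values shown sits. The two other compounds of the series are in the same position. Compound 1 `C1=C(CCN2CCN(c3cccc4c3OCCO4)CC2)c2ccccc2CC1` gives a limit in this assay, > 40 mg/kg. Compound 2 `C1=C(CCN2CCN(c3cccc4c3OCCO4)CC2)c2ccccc2C1` also gives a limit in this assay, > 2.5 mg/kg. Thus one value sits at the limit of > 2.5 mg/kg in this assay, at which 1 of the 3 values shown sits, and one at the limit of > 40 mg/kg in this assay, at which 1 of the 3 values shown sits, and no step between measured compounds can be read from these three results, since none of them is a measured number.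

Compound 4 `c1ccc2c(c1)CC2CCN1CCN(c2cccc3c2OCCCO3)CC1` is the next compound to be tested. It differs from compound 3 in a single place: a group of 9 heavy atoms (9 carbon; one four-membered non-aromatic ring of carbon only, one six-membered aromatic ring of carbon only) in place of a group of 8 heavy atoms (8 carbon; one four-membered non-aromatic ring of carbon only, one six-membered aromatic ring of carbon only), on a saturated chain carbon bound to an amine nitrogen in a ring. For the measured compounds named here, with no measured step in hand, the expected change is none beyond the usual scatter of this assay, and the step from compound 3 to compound 4 is estimated as a step that the limit leaves unreadable from compound 3 to compound 4. On that basis compound 4 is expected to give about 20 mg/kg in this assay, with a range from 5 mg/kg to 80 mg/kg, and most probably again only a limit rather than a number.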

Compound 4, minimum effective dose: 40 mg/kg
Beside the measured number, compound 4's estimate is 2.0-fold (0.30 log units) below it; low and high end bracket the measured number.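

For the compounds shown here, compound 4 is the only one of the four compounds with a measured number in this assay, so no step from compound 3 to compound 4 can be read. Compound 3 remains a limit: the limit of > 10 mg/kg in this assay, at which 1 of the 4 values shown sits.

The compounds shown leave open whether the group of 9 heavy atoms changes the dose needed at all compared with the group of 8 heavy atoms.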